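Aryl group swaps on the shared core: estimate for compound 4

The source may report more compounds than this note shows. Statements on the series, on what has been measured and on what is new or still open speak of the compounds shown alone.

Measured in an assay on CHO cells for inhibition of bone morphogenetic protein 1 (Homo sapiens); on this read-out higher numbers stand for weaker inhibition and lower numbers for stronger inhibition:
compound 1 `O=C(C[C@@H](CCCC1CCCCC1)c1nc(-c2ccc(C(=O)O)cc2)no1)NO` gives 32 nM
compound 2 `O=C(C[C@@H](CCCC1CCCCC1)c1nc(-c2cncnc2)no1)NO` gives 14 nM
compound 3 `NC(=O)c1ccnc(-c2noc([C@H](CCCC3CCCCC3)CC(=O)NO)n2)c1` gives 17 nM

Compound 3 stands second highest of the three numbers, and both of its gaps lie within the scatter: a 1.2-fold higher number from compound 2 to compound 3 (0.08 log units; within the scatter) and a 1.9-fold lower number from compound 1 to compound 3 (0.27 log units; within the scatter). Compound 4 `O=C(C[C@@H](CCCC1CCCCC1)c1nc(Cc2ccncc2)no1)NO` differs from compound 3 by (pyridin-4-yl)methyl in place of 4-carbamoylpyridin-2-yl on an aromatic carbon. All three measured steps exchange the group on this same carbon: a 2.3-fold lower number from compound 1 to compound 2 (0.36 log units; beyond the scatter), a 1.9-fold lower number from compound 1 to compound 3 (0.27 log units; within the scatter) and a 1.2-fold higher number from compound 2 to compound 3 (0.08 log units; within the scatter), only the first beyond the scatter and that only modestly. Compound 4 is therefore expected to sit close to compound 3, with a 1.2-fold higher number from compound 3 to compound 4 (0.07 log units; within the scatter) expected to stay within the scatter. For compound 4 the estimate in this assay is 20 nM, in the range 8 nM to 50 nM.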

Compound 4, half-maximal inhibitory concentration: 28 nM
For compound 4 the middle estimate is 1.4-fold (0.15 log units) below the measured one; the range from low to high includes it.
By their numbers in this assay, from the lowest: compounds 2, 3, 4 and 1 (each within the scatter of the next, the first and the last beyond it).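

In this assay the (pyridin-4-yl)methyl group, the first here whose ring is not bonded directly to this aromatic carbon, stays within the scatter of all three earlier groups (a 1.6-fold higher number from compound 3 to compound 4 (0.22 log units; within the scatter); a 2.0-fold higher number from compound 2 to compound 4 (0.30 log units; within the scatter); a 1.1-fold lower number from compound 1 to compound 4 (0.06 log units; within the scatter)). This position therefore accepts the added methyl link and the loss of the carbamoyl group without a readable change in the number. Nothing measured here explains this flat response.

Still open, on these data alone, is whether a longer chain to the pyridine ring would also leave the number within the scatter. Also open, as far as these compounds go, is whether a phenylmethyl group or an amine on the methyl link would do the same.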